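Nitro for methoxy on the benzamide: two-core comparison

This account rests on a few compounds, and the source may have more. Where it says the series, first, only, none or still open, it means among the compounds named here.

The series rests on two amides of a shared bicyclic core. Compound 1 `COc1ccc(C(=O)Nc2nc3cc(C)cc(C)c3s2)cc1` and compound 3 `Cc1cc(C)c2sc(NC(=O)c3ccc([N+](=O)[O-])cc3)nc2c1` share one core; compound 2 `COc1ccc(C(=O)Nc2nc3cc(OC)ccc3s2)cc1` and the not yet measured compound 4 `COc1ccc2sc(NC(=O)c3ccc([N+](=O)[O-])cc3)nc2c1` share the other. How the two cores differ is not broken down here.

In a functional assay on NUGC-3 cells (Homo sapiens) for antiproliferative activity, read by sulforhodamine B assay (a lower number here means a stronger inhibitor of growth, a higher number a weaker inhibitor of growth), compound 1 gives > 10 ug/mL, which is a limit of the assay and not a number. In this assay compound 2 likewise gives > 10 ug/mL, again a limit. Compound 3 gives 1.32 ug/mL in this assay.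

Within the data shown here, the one counted change within the measured set is nitro in place of methoxy on an aromatic carbon. It made an at least 7.5-fold lower number from compound 1 to compound 3 (0.87 log units; beyond the scatter). The step is stated as an "at least" because of the limit of > 10 ug/mL in this assay, at which 2 of the 3 values shown sit.

From compound 2 to compound 4 the change is nitro in place of methoxy on an aromatic carbon, the same change on a different core, as both place descriptions read alike. Nothing in the data says whether the second core answers the change as the first did, and the starting value of compound 2 is only a limit, so the expectation is set beside the measured step rather than above it.

For compound 4 the step expected is an at least 5.0-fold lower number from compound 2 to compound 4 (0.69 log units; beyond the scatter), resting on the step from compound 1 to compound 3 of an at least 7.5-fold lower number from compound 1 to compound 3 (0.87 log units; beyond the scatter). Compound 4 is estimated at 2 ug/mL, with the likely range from 0.7 ug/mL to 8 ug/mL.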

Compound 4, concentration for 50% growth inhibition: > 10 ug/mL
Compound 4 gave a limit, no number; the forecaster's own chance of this, stated with the estimate: 20%; at least 5.0-fold (0.69 log units) between middle value and limit.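

In this assay compound 4 gives > 10 ug/mL as a limit of the assay and not a number. Among these compounds, compound 2 also stands at a limit, so no step from compound 2 to compound 4 can be read: the limit of > 10 ug/mL in this assay, at which 3 of the 4 values shown sit.

The compounds shown leave open whether nitro in place of methoxy changes growth inhibition at all on the core of compound 2.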